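A few compounds are considered here, and "the series" means these few. Any claim that something is new, unique, unknown or untested is made for them only; others in the source may bear on it.

Measured so far in a functional assay on PC-3 cells (Homo sapiens) for cytotoxicity, read by MTT assay, with a stated time of 72 h; a lower number here means a stronger inhibitor of growth, a higher number a weaker inhibitor of growth:
compound 1 `C[Se]/C(=N\C(=O)c1cc2ccccc2s1)NC(=O)c1cc2ccccc2s1` gives 37200 nM
compound 2 `CS/C(=N\C(=O)c1cc2ccccc2s1)NC(=O)c1cc2ccccc2s1` gives 8580 nM
compound 3 `C[Se]/C(=N\C(=O)c1cccs1)NC(=O)c1cccs1` gives 1340 nM

Compound 3 stands lowest of the three numbers in this assay, beyond the scatter from both compound 2 and compound 1. Compound 4 `CS/C(=N\C(=O)c1cccs1)NC(=O)c1cccs1` differs from compound 3 by a group of 2 heavy atoms (1 carbon, 1 sulfur; no ring) in place of a group of 2 heavy atoms (1 carbon, 1 selenium; no ring), on a carbon with a double bond to nitrogen. Going by the values given here, the one measured step of the same kind, on the larger shared core, is a 4.3-fold lower number from compound 1 to compound 2 (0.64 log units; beyond the scatter). That step bears directly on the present one, and a change in the same direction, of modest size, is therefore expected in this assay, though whether it transfers in full to the smaller core of compound 3 is not known. Compound 4 is estimated at 500 nM, range 150 nM to 1800 nM, which would mean an expected step of a 2.7-fold lower number from compound 3 to compound 4 (0.43 log units; beyond the scatter).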

Compound 4, concentration for 50% growth inhibition: 39000 nM
Compound 4: the middle estimate sits 78-fold (1.89 log units) below what was measured; the whole stated range lies below it.
By their numbers in this assay, from the lowest: compound 3; then compound 2; then compounds 1 and 4 (each within the scatter of the next).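

In this assay the change to methylsulfanyl on a carbon with a double bond to nitrogen gives a 29-fold higher number from compound 3 to compound 4 (1.46 log units; beyond the scatter) and leaves the selenium compound with the lower number on this core. At this position, the direction of the change therefore does not carry from one core to the other: the same change on two cores in this assay, a 4.3-fold lower number (0.64 log units; beyond the scatter) from compound 1 to compound 2 and a 29-fold higher number (1.46 log units; beyond the scatter) from compound 3 to compound 4, 130-fold (2.10 log units) apart, beyond the scatter of two such steps

Which feature of the two cores goes with the reversal remains open. Also open, as far as these compounds go, is whether a longer chain on the sulfur or selenium, or an amine in the same place, would follow either direction.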